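The source may hold more compounds than are shown below. What is called first, only, known or untested is meant among the compounds shown, and "the series" means these compounds.

Working notes on the series. Compound 1 `CCCCCCc1cc2cn([C@H]3C[C@H](O)[C@@H](CO)O3)c(=O)nc2o1` is the reference point. In a functional assay on HEL cells (Homo sapiens) for cytotoxicity (a lower number here means that less compound is tolerated, a higher number that more compound is tolerated), compound 1 gives only a limit, > 200000 nM. Compound 2 `CCCCCCCCc1cc2cn([C@H]3C[C@H](O)[C@@H](CO)O3)c(=O)nc2o1` likewise gives only a limit in this assay, > 50000 nM. The step that the two limits leave unreadable from compound 1 to compound 2 therefore cannot be read; both of its ends are limits, as the limit of > 200000 nM in this assay, at which 1 of the 2 values shown sits, and the limit of > 50000 nM in this assay, at which 1 of the 2 values shown sits, show. Compound 3 `C=CCCCCc1cc2cn([C@H]3C[C@H](O)[C@@H](CO)O3)c(=O)nc2o1` is the next member to be examined. The change from compound 1 to compound 3 is vinyl in place of ethyl on a saturated chain carbon, four bonds along the chain from an aromatic carbon. Going by the values given here, the only measured step, a step that the two limits leave unreadable from compound 1 to compound 2, bears on this change only loosely: it alters the same chain at a different place, and its size is not readable, so it gives no sign of any measurable effect on tolerance. For compound 3 in this assay the expected step is a number no higher from compound 1 to compound 3 (the limit leaves the size open), that is none beyond the scatter. The estimate for compound 3 is 200000 nM, within 50000 nM to 1000000 nM, most likely reported again as a limit.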

Compound 3, half-maximal cytotoxic concentration: > 200000 nM
Compound 3: only a limit was reported; the forecaster's own chance of this, stated with the estimate: 85%; the middle value sits exactly at the limit.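

Going by these compounds alone, compound 3 also gives only a limit in this assay, > 200000 nM, so no step linking it to compound 1 or compound 2 can be read. The compounds shown leave open the concentration at which any of them becomes cytotoxic, and whether vinyl in place of ethyl changes it.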